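From compound 3 to a methyl tetrahydroquinoline on the thiocarbonyl

The source may hold more compounds than are shown below. What is called first, only, known or untested is meant among the compounds shown, and "the series" means these compounds.

In a functional assay on KYSE-450 cells (Homo sapiens) for inhibition, read by CCK-8 assay, with a stated time of 48 h (on this read-out lower numbers stand for stronger inhibition and higher numbers for weaker inhibition), compound 1 `COc1ccc(CN(C(=O)CSC(=S)N2CCCC2)c2cc(OC)c(OC)c(OC)c2)cc1` gives 13800 nM. Compound 2 `COc1ccc(CN(C(=O)CSC(=S)N2CCc3ccccc32)c2cc(OC)c(OC)c(OC)c2)cc1` gives 6940 nM, and the pair shows a 2.0-fold lower number from compound 1 to compound 2 (0.30 log units; within the scatter). Compound 3 `COc1ccc(CN(C(=O)CSC(=S)N2CCc3cc(Br)ccc32)c2cc(OC)c(OC)c(OC)c2)cc1` stands at > 20000 nM, which is a limit of the assay and not a number.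

Compound 4 `COc1ccc(CN(C(=O)CSC(=S)N2CCCc3cc(C)ccc32)c2cc(OC)c(OC)c(OC)c2)cc1` has 6-methyl-1,2,3,4-tetrahydroquinolin-1-yl in place of 5-bromo-2,3-dihydro-1H-indol-1-yl on a thiocarbonyl carbon. The closest measured precedent is bromo in place of hydrogen on an aromatic carbon, which gave an at least 2.8-fold higher number from compound 2 to compound 3 (0.45 log units; beyond the scatter). The replacement of pyrrolidin-1-yl by the brominated group gave an at least 1.4-fold higher number from compound 1 to compound 3 (0.16 log units; that floor lies within the scatter). Compound 4 carries no bromo, so a return toward compound 2, at 6940 nM, is the working expectation. Within the data shown here, no measured step covers the six-membered ring or the methyl, and the limit on compound 3 leaves the size of the step open. The expected change is an at least 2.2-fold lower number from compound 3 to compound 4 (0.34 log units; beyond the scatter), toward lower numbers. For compound 4 the estimated value is 9000 nM, with an expected range of 3500 nM to 20000 nM.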

Compound 4, half-maximal inhibitory concentration: 5210 nM
Estimate against measurement, compound 4: 1.7-fold (0.24 log units) above, and the stated range covers the measured number.
By their numbers in this assay, from the lowest: compounds 4, 2 and 1 (each within the scatter of the next, the first and the last beyond it). At a limit, above all of these: compound 3.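

With 6-methyl-1,2,3,4-tetrahydroquinolin-1-yl on the thiocarbonyl carbon, the series has its first step away from pyrrolidin-1-yl that lies beyond the scatter: a 2.6-fold lower number from compound 1 to compound 4 (0.42 log units; beyond the scatter). Against 2,3-dihydro-1H-indol-1-yl the same group gives a 1.3-fold lower number from compound 2 to compound 4 (0.12 log units; within the scatter), so the six-membered non-aromatic ring with its methyl shows no readable change from that group at this position. The step of an at least 3.8-fold lower number from compound 3 to compound 4 (0.58 log units; beyond the scatter) is only a floor because compound 3 rests on a limit: the limit of > 20000 nM in this assay, at which 1 of the 4 values shown sits.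

The compounds shown do not separate the contribution of the six-membered ring from that of the methyl. Also open, as far as these compounds go, is how morpholin-4-yl or a dimethylamino group would read on the thiocarbonyl carbon.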